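Permeability notes: aryl to aryloxy swap on the shared core

The compounds below may be only part of what the source reports. "The series", "measured", "known", "first", "only" and "open" are said of these compounds alone.

Three compounds of the series have numbers in an ADME assay for permeability, using PAMPA, with a stated time of 30 min, at pH 7.4; on this read-out lower numbers stand for lower permeability and higher numbers for higher permeability. Compound 1 `c1ccc(CCc2ccc3c(NCCCNCc4ccco4)ccnc3c2)cc1` gives 23 10^-6 cm/s. Compound 2 `COc1ccc(Oc2ccc3c(NCCCNCc4cc(F)ccc4OC)ccnc3c2)cc1` gives 317 10^-6 cm/s. Compound 3 `COc1cccc(CNCCCNc2ccnc3cc(-c4ccc(C(C)(C)C)cc4)ccc23)c1O` gives 237 10^-6 cm/s, which places compound 3 second highest of the three: the nearest number is that of compound 2, which sits within the scatter of compound 3, while the furthest is that of compound 1, which lies beyond the scatter and below compound 3.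

Compound 4 `COc1cccc(Oc2ccc3c(NCCCNCc4cccc(OC)c4O)ccnc3c2)c1` has no number yet in this assay. It differs from compound 3 in one place: 3-methoxyphenoxy in place of 4-(tert-butyl)phenyl on an aromatic carbon. For the measured compounds named here, no measured pair in the set carries this exact change, so no step can be read off directly. The closest guide is compound 2, which also carries a methoxyphenoxy group on the shared core and gives 317 10^-6 cm/s, a number within the scatter of compound 3. On that basis the expected step is a 1.1-fold higher number from compound 3 to compound 4 (0.04 log units; within the scatter), a change that stays within the usual scatter in this assay rather than a move in either direction. Compound 4 is therefore estimated at 260 10^-6 cm/s, with an expected range from 130 10^-6 cm/s to 480 10^-6 cm/s.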

Compound 4, apparent permeability: 317 10^-6 cm/s
Compound 4: the middle estimate sits 1.2-fold (0.09 log units) below what was measured; measured number inside the range.
By their numbers in this assay, from the lowest: compound 1; then compounds 3, 2 and 4 (each within the scatter of the next).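

In this assay, for the compounds shown here, the exchange at this position gives a 1.3-fold higher number from compound 3 to compound 4 (0.13 log units; within the scatter) and supplies the only step in the set between compounds that differ in one place, so the comparison no longer rests on compounds that differ in several places. On this aromatic carbon of the shared core, 4-(tert-butyl)phenyl with 0 hydrogen-bond acceptors gives way to 3-methoxyphenoxy with 2 hydrogen-bond acceptors, and this difference in the printed counts comes with a step that stays within the usual scatter, at least in this one pair carrying the side chain of compound 3. The set holds no measurement that speaks to the reason for this outcome.

A single pair leaves open whether the same exchange would behave alike on the side chains of compound 1 or compound 2, and it says nothing about other positions on the shared core. The compounds shown also leave open what a group of a different kind would give on this aromatic carbon, such as a carboxylic acid, a morpholine or a longer alkyl ether chain.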